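A few compounds are considered here, and "the series" means these few. Any claim that something is new, unique, unknown or untested is made for them only; others in the source may bear on it.

Three compounds have numbers in a functional assay on A549 cells (Homo sapiens) for cytotoxicity, read by MTT assay, with a stated time of 72 h; a higher number here means a weaker inhibitor, a lower number a stronger inhibitor:

Compound 1, `CC(=O)n1cc(/C=C(/C(=O)O)c2ccccc2)c2cc(OCc3ccccc3)ccc21`: 57500 nM
Compound 2, `COc1cc(/C(=C\c2cn(C(C)=O)c3ccc(OCc4ccccc4)cc23)C(=O)O)cc(OC)c1OC`: 89100 nM
Compound 3, `COc1ccccc1/C(=C\c1cn(C(C)=O)c2ccc(OCc3ccccc3)cc12)C(=O)O`: 57200 nM

Compound 3 holds the lowest of the three numbers, but it is not set apart: the step of a 1.0-fold lower number from compound 1 to compound 3 (0.00 log units; within the scatter) and the step of a 1.6-fold lower number from compound 2 to compound 3 (0.19 log units; within the scatter) both fall within the scatter, so no order among the three can be claimed.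

Compound 4 is `CC(=O)n1cc(/C=C(/C(=O)O)c2ccc(Cl)cc2)c2cc(OCc3ccccc3)ccc21`. It differs from compound 3 in one place: 4-chlorophenyl in place of 2-methoxyphenyl on a double-bonded chain carbon bound to a carbonyl carbon and a double-bonded chain carbon. All three measured steps vary the aryl group on this same chain carbon. The step of a 1.5-fold higher number from compound 1 to compound 2 (0.19 log units; within the scatter) and the step of a 1.6-fold lower number from compound 2 to compound 3 (0.19 log units; within the scatter) swap one substituted phenyl for another, and the step of a 1.0-fold lower number from compound 1 to compound 3 (0.00 log units; within the scatter) adds a methoxy to the plain phenyl; none moves the number beyond the scatter. Going by the values given here, the exchange to 4-chlorophenyl has no measured counterpart, so the expectation rests on these three.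

Compound 4 is therefore expected to sit close to compound 3, with an estimated step of a 1.0-fold lower number from compound 3 to compound 4 (0.00 log units; within the scatter), not beyond the scatter in either direction. The estimate for compound 4 in this assay is 57000 nM, ranging from 28000 nM to 115000 nM.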

Compound 4, half-maximal inhibitory concentration: 52300 nM
Beside the measured number, compound 4's estimate is 1.1-fold (0.04 log units) above it; the measured number falls inside the stated range.
By their numbers in this assay, from the lowest: compounds 4, 3, 1 and 2 (each within the scatter of the next).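

In this assay, chloro now stands on the aryl group at this position, on a double-bonded chain carbon bound to a carbonyl carbon and a double-bonded chain carbon, and the steps of a 1.1-fold lower number from compound 3 to compound 4 (0.04 log units; within the scatter) and a 1.7-fold lower number from compound 2 to compound 4 (0.23 log units; within the scatter) and a 1.1-fold lower number from compound 1 to compound 4 (0.04 log units; within the scatter) all stay within the scatter. The earlier compounds shown here carried only hydrogen or methoxy on this aryl group, so the insensitivity now extends to a chloro-bearing aryl group, for these four compounds alone. Nothing at hand bears on why the number stays so flat here.

As far as these compounds go, whether any group at this position can move the number beyond the scatter stays open, for instance a phenyl carrying an amine or a nitrile. From the compounds shown here alone, whether a change elsewhere on the shared core would do so also stays open.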